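From (3-Oxocyclobutyl)carbonyl to 4-Methylpyrimidin-2-yl on the Amine Nitrogen

The source may report more compounds than this note shows. Statements on the series, on what has been measured and on what is new or still open speak of the compounds shown alone.

Of the compounds shown here, three on a shared core have been measured in a functional assay on LNCaP cells (Homo sapiens) for antiproliferative activity, read by CCK-8 assay, with a stated time of 6 days; on this read-out lower numbers stand for stronger inhibition and higher numbers for weaker inhibition. Compound 1 `CC(O)c1cccc(C(=O)N[C@@H](C)Cn2ccc(-c3ccc(C#N)c(Cl)c3)n2)c1` gives 2280 nM, compound 2 `CC(O)c1ccc(C(=O)N[C@@H](C)Cn2ccc(-c3ccc(C#N)c(Cl)c3)n2)cc1` gives 3690 nM, and compound 3 `C[C@@H](Cn1ccc(-c2ccc(C#N)c(Cl)c2)n1)NC(=O)C1CC(=O)C1` gives 3040 nM. Compound 3 holds the second highest of the three numbers; its nearest neighbour is compound 2, with a 1.2-fold lower number from compound 2 to compound 3 (0.08 log units; within the scatter), and its furthest is compound 1, with a 1.3-fold higher number from compound 1 to compound 3 (0.12 log units; within the scatter). The remaining step, a 1.6-fold higher number from compound 1 to compound 2 (0.21 log units; within the scatter), is likewise small.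

Compound 4 `Cc1ccnc(N[C@@H](C)Cn2ccc(-c3ccc(C#N)c(Cl)c3)n2)n1` differs from compound 3 in one place: 4-methylpyrimidin-2-yl in place of (3-oxocyclobutyl)carbonyl on an amine nitrogen. All three measured steps exchange one group on a carbonyl carbon for another and stay within the scatter; none of them replaces the carbonyl itself, so none bears directly on this change, and the data give no direction for it. The expectation for compound 4 is therefore a step of a 1.2-fold lower number from compound 3 to compound 4 (0.08 log units; within the scatter), with a wide range. Compound 4 is estimated at 2500 nM, expected between 500 nM and 12000 nM in this assay.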

Compound 4, half-maximal inhibitory concentration: 1330 nM
Estimate against measurement, compound 4: 1.9-fold (0.27 log units) above; low and high end bracket the measured number.
By their numbers in this assay, from the lowest: compounds 4, 1, 3 and 2 (each within the scatter of the next, the first and the last beyond it).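

In this assay, the exchange on the amine nitrogen gives a 2.3-fold lower number from compound 3 to compound 4 (0.36 log units; beyond the scatter), a modest step but the only one here that lies beyond the scatter. It shows that this position does not need the carbonyl: with a 4-methylpyrimidin-2-yl group directly on the amine nitrogen, the number falls rather than rises, although the leaving and entering groups have equal counts of heavy atoms, hydrogen-bond donors and hydrogen-bond acceptors. Nothing available explains this step.

Among the compounds shown here, the single exchange removes the carbonyl and the four-membered ring and brings in the aromatic ring and its methyl group, so the share of each remains open. An unsubstituted pyrimidin-2-yl or a pyridin-2-yl group on the same nitrogen would begin to separate these contributions.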